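Chain lengthening in a sulfonyl imine series at the serotonin-6 receptor

A few compounds are considered here, and "the series" means these few. Any claim that something is new, unique, unknown or untested is made for them only; others in the source may bear on it.

The study compares three measured compounds and one that awaits measurement. Compound 1 `CNc1nc2ccccn2c(=N)c1S(=O)(=O)c1ccccc1` gives 2.4 nM in an assay on HeLa cells for displacement of a labelled ligand from 5-hydroxytryptamine receptor 6 (Homo sapiens); on this read-out lower numbers stand for stronger inhibition and higher numbers for weaker inhibition. Compound 2 `CCNc1nc2ccccn2c(=N)c1S(=O)(=O)c1ccccc1` gives 2 nM in this assay. The two differ by methyl in place of hydrogen on a saturated chain carbon bound to a nitrogen on an aromatic ring, and the step of a 1.2-fold lower number from compound 1 to compound 2 (0.08 log units; within the scatter) is small. Compound 3 `CCc1ccn2c(=N)c(S(=O)(=O)c3ccccc3)c(SC)nc2c1` gives 80 nM in this assay, the highest of the three numbers; the difference between its core and the core of compound 1 is not broken down here.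

Compound 4 `CCCc1ccn2c(=N)c(S(=O)(=O)c3ccccc3)c(SC)nc2c1` is the unmeasured member. It differs from compound 3 by methyl in place of hydrogen on a saturated chain carbon, two bonds along the chain from an aromatic carbon. This is the same kind of change as that from compound 1 to compound 2, but not the same: there the new carbon sits on a saturated chain carbon bound to a nitrogen on an aromatic ring, here on a saturated chain carbon two bonds along the chain from an aromatic carbon. Because a 1.2-fold lower number from compound 1 to compound 2 (0.08 log units; within the scatter) stayed within the scatter, the author expects a comparably small step a 1.1-fold lower number from compound 3 to compound 4 (0.06 log units; within the scatter). Compound 4 is therefore estimated at 70 nM, expected to fall between 30 nM and 160 nM.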

Compound 4, half-maximal inhibitory concentration: 700 nM
The estimate for compound 4 lay 10-fold (1.00 log units) below the measured number; the whole stated range lies below it.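

In this assay, ethyl to propyl on the core of compound 3 gave an 8.8-fold higher number from compound 3 to compound 4 (0.94 log units; beyond the scatter), so the near-silent result of the same added methyl on the core of compound 1 did not carry over to this core. The two steps differ by more than their scatter allows: the same change on two cores in this assay, a 1.2-fold lower number (0.08 log units; within the scatter) from compound 1 to compound 2 and an 8.8-fold higher number (0.94 log units; beyond the scatter) from compound 3 to compound 4, 11-fold (1.02 log units) apart, beyond the scatter of two such steps. This does not show that the core alone sets the outcome, since the two pairs also differ in the place of the change, on a saturated chain carbon bound to a nitrogen on an aromatic ring in one and two bonds along the chain from an aromatic carbon in the other, and one pair of each kind supports no general rule for the series.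

The compounds shown leave open whether a longer chain, such as butyl, would continue the trend from compound 3 to compound 4. They also leave open how a propyl chain on the amine nitrogen would behave on the core of compound 1.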